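The source may hold more compounds than are shown below. What is called first, only, known or untested is meant among the compounds shown, and "the series" means these compounds.

Measured compounds in this series:
compound 1 `CC(C)=CCC/C(C)=C/CC/C(C)=C/CSc1ccccc1C(=O)NCCN`: > 50000 nM
compound 2 `CC(C)=CCC/C(C)=C/CC/C(C)=C/CSc1ccccc1C(=O)NCCCN`: 17200 nM
compound 3 `CC(C)=CCC/C(C)=C/CC/C(C)=C/CSc1ccccc1C(=O)NCCCCN`: 13100 nM

In a functional assay on EJ cells (Homo sapiens) for cytotoxicity, read by MTT assay, with a stated time of 48 h (on this read-out higher numbers stand for weaker inhibition and lower numbers for stronger inhibition), compound 1 gives only a limit, > 50000 nM, not a number. Compound 2 holds the highest of the two real numbers; its nearest neighbour is compound 3, with a 1.3-fold lower number from compound 2 to compound 3 (0.12 log units; within the scatter). The unmeasured compound 4 `CC(C)=CCC/C(C)=C/CC/C(C)=C/CSc1ccccc1C(=O)NCCCCCCN` differs from compound 2 in one place: 3-aminopropyl in place of amino on a saturated chain carbon, three bonds along the chain from an amide-type nitrogen.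

Among the compounds with values here, three measured steps bear on this lengthening of the chain that carries the terminal amine. From compound 1 the step to compound 2 is an at least 2.9-fold lower number from compound 1 to compound 2 (0.46 log units; beyond the scatter), and to compound 3 it is an at least 3.8-fold lower number from compound 1 to compound 3 (0.58 log units; beyond the scatter). Both of these start from the limit of compound 1 (the limit of > 50000 nM in this assay, at which 1 of the 3 values shown sits). The step between the two real numbers, a 1.3-fold lower number from compound 2 to compound 3 (0.12 log units; within the scatter), is small. Lengthening the chain has not raised the number in any measured step, and the clearest drops sit at the shortest chains; compound 4 adds three further carbons. A lower number in this assay is therefore expected for compound 4, of about a 1.9-fold lower number from compound 2 to compound 4 (0.28 log units; within the scatter), though it may not clear the scatter. Compound 4 is estimated at 9000 nM, with a range of 4000 nM to 20000 nM.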

Compound 4, half-maximal inhibitory concentration: 10100 nM
Beside the measured number, compound 4's estimate is 1.1-fold (0.05 log units) below it; measured number inside the range.
By their numbers in this assay, from the lowest: compounds 4, 3 and 2 (each within the scatter of the next). At a limit, above all of these: compound 1.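

In this assay, compound 4 carries the chain out to 6-aminohexyl, and the two steps that join it to the real numbers, a 1.7-fold lower number from compound 2 to compound 4 (0.23 log units; within the scatter) and a 1.3-fold lower number from compound 3 to compound 4 (0.11 log units; within the scatter), are both small, so compounds 2, 3 and 4 now form a set of three values that cannot be told apart. Adding three further carbons to the chain of compound 2 therefore gives no step beyond the scatter, and chain length among these three compounds does not separate them on this read-out. Only the shortest chain stands apart, and the step from it, an at least 4.9-fold lower number from compound 1 to compound 4 (0.69 log units; beyond the scatter), is a bound and not a measured size, since compound 1 gives a limit and not a number: the limit of > 50000 nM in this assay, at which 1 of the 4 values shown sits.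

The compounds shown leave open how far the true number of compound 1 lies from the other three, and whether a chain longer than 6-aminohexyl would stay in the same range. They also leave open whether the terminal amine matters in itself, as a hydroxyl, a carboxylic acid or a dimethylamino group at the chain end would test.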